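A few compounds are considered here, and "the series" means these few. Any claim that something is new, unique, unknown or untested is made for them only; others in the source may bear on it.

Compound 1 `CC(C)(C)C(=O)N(CCCCCCN1C[C@H](O)[C@@H](O)[C@H](O)[C@H]1CO)C1CCCCC1` was examined in an ADME assay on MDBK cells (Bos taurus) for cytotoxicity, read by MTT assay (a higher number here means that more compound is tolerated, a lower number that less compound is tolerated), where compound 1 gives > 500000 nM, which is a limit of the assay rather than a number. Compound 2 `O=C(c1ccccc1)N(CCCCCCN1C[C@H](O)[C@@H](O)[C@H](O)[C@H]1CO)C1CCCCC1` gives > 500000 nM in this assay, again a limit. Within the data shown here, compound 3 `O=S(=O)(c1ccccc1)N(CCCCCCN1C[C@H](O)[C@@H](O)[C@H](O)[C@H]1CO)C1CCCCC1` is the only one with a readable number, giving 200000 nM in this assay. The step from compound 1 to compound 3 is an at least 2.5-fold lower number from compound 1 to compound 3 (0.39 log units; beyond the scatter), and that from compound 2 to compound 3 is an at least 2.5-fold lower number from compound 2 to compound 3 (0.39 log units; beyond the scatter); both rest on (the limit of > 500000 nM in this assay, at which 2 of the 3 values shown sit). Between compound 1 and compound 2 the step is a step that the two limits leave unreadable from compound 1 to compound 2.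

Compound 4 `CCCNC(=O)N(CCCCCCN1C[C@H](O)[C@@H](O)[C@H](O)[C@H]1CO)C1CCCCC1` differs from compound 3 by propylcarbamoyl in place of phenylsulfonyl on an amine nitrogen. Among the measured compounds shown here, the change removes the phenylsulfonyl that, in the two readable steps, went with the only lower number, and puts a carbonyl-bearing group back on the amine nitrogen, as in compound 1 and compound 2. Both those steps were at least modest, so a rise of comparable size back toward the limit is expected, a 2.5-fold higher number from compound 3 to compound 4 (0.40 log units; beyond the scatter). Compound 4 is therefore estimated at 500000 nM in this assay, between 200000 nM and 1000000 nM, with a fair chance that only a limit is reported.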

Compound 4, half-maximal cytotoxic concentration: > 500000 nM
Compound 4 was reported as a limit; the forecaster's own chance of this, stated with the estimate: 60%; the middle value lies on the limit itself.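

Putting propylcarbamoyl in place of phenylsulfonyl on the amine nitrogen gives an at least 2.5-fold higher number from compound 3 to compound 4 (0.39 log units; beyond the scatter) in this assay, so a group with no ring and with a nitrogen on its carbonyl now joins the comparison with compound 3. For compound 4, > 500000 nM is a limit of the assay. With tert-butyl, phenyl or propylamino on the carbonyl, compound 1, compound 2 and compound 4 all stand apart from the phenylsulfonyl of compound 3, but the steps among these three cannot be read because of this shared ceiling: the limit of > 500000 nM in this assay, at which 3 of the 4 values shown sit.

From the compounds shown here alone, whether the lower number of compound 3 belongs to the sulfonyl itself or to the phenyl on it stays open, and a methylsulfonyl group at this place would bear on that. Going by these compounds, how far compound 1, compound 2 and compound 4 differ from one another also stays open.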